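A few compounds are considered here, and "the series" means these few. Any claim that something is new, unique, unknown or untested is made for them only; others in the source may bear on it.

Measured in an ADME assay on HCT-116 cells (Homo sapiens) for cytotoxicity, read by CellTiter-Glo, with a stated time of 72 h; on this read-out higher numbers stand for weaker inhibition and lower numbers for stronger inhibition:
- compound 1 `CC1CCN(C2CCN(S(=O)(=O)c3cccc4ccccc34)CC2)CC1`: > 10000 nM
- compound 2 `CC1CCN(C2CCN(S(=O)(=O)c3cc(F)c(Br)c(F)c3)CC2)CC1`: > 5000 nM
- compound 3 `CCCC(=O)NC1CCN(S(=O)(=O)c2c(C)cc(C)cc2C)CC1`: > 5000 nM

All three entries are limits, not numbers. Compound 1 stands at the limit of > 10000 nM in this assay, at which 1 of the 3 values shown sits. The other two compounds share (the limit of > 5000 nM in this assay, at which 2 of the 3 values shown sit).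

Compound 4 `CC1CCN(C2CCN(S(=O)(=O)c3ccc(Cl)c4ccccc34)CC2)CC1` has chloro in place of hydrogen on an aromatic carbon of compound 1, para to a large group (chloro in place of hydrogen on an aromatic carbon). Among the measured compounds shown here, no two measured compounds differ in one place, so the series gives no direct size for this change. No step beyond the scatter is expected in this assay. The expectation rests on compound 1, whose > 10000 nM is a limit. The expected change is a number no higher from compound 1 to compound 4 (the limit leaves the size open). For compound 4 the estimate is 10000 nM, with an expected range from 4000 nM to 25000 nM.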

Compound 4, half-maximal inhibitory concentration: > 10000 nM
Compound 4: no number, only a limit (the forecaster's own chance of this, stated with the estimate: 75%); the middle value sits exactly at the limit.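

In this assay, compound 1 and compound 4 both stand as limits; the step between them, chloro in place of hydrogen on an aromatic carbon, cannot be read. The compounds shown leave open the size of that change, since none gives a number rather than a limit.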